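This account rests on a few compounds, and the source may have more. Where it says the series, first, only, none or still open, it means among the compounds named here.

In an ADME assay on HEL cells (Homo sapiens) for cytotoxicity, with a stated time of 3 days (a higher number here means that more compound is tolerated, a lower number that less compound is tolerated), compound 1 `CCC1(Cc2ccccc2)OS(=O)(=O)C=C1OCCCCc1ccccc1` gives >= 20000 nM, which is a limit of the assay rather than a number. Compound 2 `CCC1(Cc2ccccc2)OS(=O)(=O)CC1=O` gives > 100000 nM in this assay, likewise a limit. Both values shown for this assay are therefore limits, and compound 1 stands at one of them the limit of >= 20000 nM in this assay, at which 1 of the 2 values shown sits, while compound 2 sits at the other (the limit of > 100000 nM in this assay, at which 1 of the 2 values shown sits). Within the data shown here, no step between two measured compounds is available from these two limits, so no measured size of change exists to lean on. Compound 3 `CCC1(Cc2ccccc2)OS(=O)(=O)C=C1OCC1CCCCC1` differs from compound 1 by cyclohexyl in place of 3-phenylpropyl on a saturated chain carbon bound to an oxygen on an unsaturated carbon. With compound 1 at a limit >= 20000 nM, the step from compound 1 to compound 3 is expected to be small, a number no higher from compound 1 to compound 3 (the limit leaves the size open), and most likely none beyond the usual scatter. Compound 3 is thus estimated at 20000 nM in this assay, within a range from 8000 nM to 100000 nM.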

Compound 3, minimum cytotoxic concentration: >= 200000 nM
Compound 3: only a limit was reported; the forecaster's own chance of this, stated with the estimate: 75%; middle value at least 10-fold (1.00 log units) away from the limit.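

In this assay, among these compounds, compound 1 and compound 3 are both reported only as limits, so no step between compound 1 and compound 3 can be read. The compounds shown leave open whether cyclohexyl in place of 3-phenylpropyl changes the minimum cytotoxic concentration at all, and in which direction.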